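Quinolin-8-yl for Quinolin-4-yl on the Carbonyl Carbon

The source may hold more compounds than are shown below. What is called first, only, known or untested is meant among the compounds shown, and "the series" means these compounds.

Of the compounds shown here, three built on one shared core have been measured in a functional assay on the whole organism (blood) with Rattus norvegicus as the target, with stated times of 24 h and 1 h, at a dose of 5 mg/kg by the intraperitoneal route; on this read-out higher numbers stand for a stronger effect at the one dose given and lower numbers for a weaker effect. Compound 1 `COc1ccc(Cl)cc1C(=O)NCCC1CCN(S(=O)(=O)NC(=O)NC2CCCCC2)CC1` gives 25%, compound 2 `O=C(NC1CCCCC1)NS(=O)(=O)N1CCC(CCNC(=O)C(F)(F)F)CC1` gives 13%, and compound 3 `O=C(NC1CCCCC1)NS(=O)(=O)N1CCC(CCNC(=O)c2ccnc3ccccc23)CC1` gives 16%. On the numbers alone compound 3 sits between the other two, but both a number 9 percentage points lower from compound 1 to compound 3 (within the scatter) and a number 3 percentage points higher from compound 2 to compound 3 (within the scatter) lie within the scatter, so only a number 12 percentage points lower from compound 1 to compound 2 (beyond the scatter) separates any pair. Compound 4 `O=C(NC1CCCCC1)NS(=O)(=O)N1CCC(CCNC(=O)c2cccc3cccnc23)CC1` is the next candidate; it differs from compound 3 in one place: quinolin-8-yl in place of quinolin-4-yl on a carbonyl carbon. Going by the values given here, no measured step exchanges one quinolinyl attachment for another, so the closest guides are the three swaps already made at this carbonyl carbon, which moved the read-out by at most a modest amount. Because the earlier swap recorded as a number 3 percentage points higher from compound 2 to compound 3 (within the scatter) stayed within the scatter, the author expects no change at the digits printed from compound 3 to compound 4 (within the scatter) in this assay. Compound 4 is therefore estimated at 16%, with a likely range from 6% to 28%.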

Compound 4, a percentage reported as activity, at one dose (the size of the read-out at that dose, not a potency): 37%
The estimate for compound 4 lay 21 percentage points below the measured number; measured number above the stated range.
By their numbers in this assay, from the lowest: compounds 2, 3 and 1 (each within the scatter of the next, the first and the last beyond it); then compound 4.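

In this assay, moving the attachment of the quinoline, with the same atoms joined differently, gives the first rise beyond the scatter at this carbonyl carbon (a number 21 percentage points higher from compound 3 to compound 4 (beyond the scatter)). Compound 4 also stands clear of the trifluoromethyl amide (a number 24 percentage points higher from compound 2 to compound 4 (beyond the scatter)) and of the 5-chloro-2-methoxyphenyl amide (a number 12 percentage points higher from compound 1 to compound 4 (beyond the scatter)), so it alone is separated from every other compound shown, and the attachment point of a quinolinyl group can matter as much here as the choice of group. Nothing measured here accounts for this rise.

The compounds shown leave open whether the gain depends on the ring nitrogen of quinolin-8-yl, which a naphthalen-1-yl group on the same carbonyl carbon would test. On these data alone, how other attachments, such as quinolin-5-yl, would read also remains open.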